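The source may report more compounds than this note shows. Statements on the series, on what has been measured and on what is new or still open speak of the compounds shown alone.

Measured so far in a functional assay on PC-12 cells (Rattus norvegicus) for cytotoxicity, read by MTT assay, with stated times of 3 h and 2 h, tested at 0.1 uM; on this read-out higher numbers stand for a stronger effect at the one concentration tested and lower numbers for a weaker effect:

Compound 1 `CCOC(=O)c1cc2ccc(OCCCn3cc(CNC(=O)CCCCC4CCSS4)nn3)cc2oc1=O`: 28%
Compound 2 `O=C(CCCCC1CCSS1)NCc1cn(CCCOc2ccc3cc(C(=O)O)c(=O)oc3c2)nn1`: 43.4%

Compound 2 stands highest of the two numbers, its nearest neighbour being compound 1. Going by the values given here, the only measured step, a number 15.4 percentage points higher from compound 1 to compound 2 (beyond the scatter), came from hydrogen in place of ethyl on an oxygen next to a carbonyl group. Compound 3 `O=C(CCCCC1CCSS1)NCc1cn(CCCOc2ccc3cc(-c4ccc(Br)cc4)c(=O)oc3c2)nn1` differs from compound 2 by 4-bromophenyl in place of carboxy on an aromatic carbon. Among the compounds with values here, no measured step touches this kind of change, so nothing indicates a direction; the expected step of a number 7.4 percentage points lower from compound 2 to compound 3 (within the scatter) is therefore small and uncertain. For compound 3 the estimate in this assay is 36%, within 15% to 57%.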

Compound 3, a percentage reported as activity, at one concentration (the size of the read-out at that concentration, not a potency): 39.5%
Beside the measured number, compound 3's estimate is 3.5 percentage points below it, within the range that was stated.
By their numbers in this assay, from the lowest: compound 1; then compounds 3 and 2 (each within the scatter of the next).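

In this assay, 4-bromophenyl on this aromatic carbon, with no hydrogen-bond donor, replaces carboxy with a number 3.9 percentage points lower from compound 2 to compound 3 (within the scatter) and so the free carboxy is not needed to keep this level of effect. Replacing ethoxycarbonyl with 4-bromophenyl gives a number 11.5 percentage points higher from compound 1 to compound 3 (beyond the scatter) and leaves compound 1 as the only one set apart at this position. No measurement here explains why these groups fall this way.

From the compounds shown here alone, whether an amine, a methyl group or a phenyl ring without bromine would match compound 1 or compound 2 remains open.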